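Swapping the amide substituent back to an aryl group

The compounds below may be only part of what the source reports. "The series", "measured", "known", "first", "only" and "open" are said of these compounds alone.

Within the data shown here, in a functional assay on HEK293 cells for agonist activity at D(4) dopamine receptor (Homo sapiens), read by FLIPR (a higher number here means a larger maximal response, a lower number a smaller maximal response), compound 1 `Cc1cc(NC(=O)CN2CCC(c3cccc[n+]3[O-])CC2)ccc1F` gives 75%, whereas compound 2 `O=C(CN1CCC(c2cccc[n+]2[O-])CC1)NC1CCCCC1` gives 58%, the lowest of the two numbers so far; the step of a number 17 percentage points lower from compound 1 to compound 2 (beyond the scatter) is the only measured one and bears directly on this question. Compound 3 `O=C(CN1CCC(c2cccc[n+]2[O-])CC1)Nc1cccc(Cl)c1Cl` differs from compound 2 by 2,3-dichlorophenyl in place of cyclohexyl on an amide-type nitrogen, again an aromatic ring on the amide nitrogen. Because the change a number 17 percentage points lower from compound 1 to compound 2 (beyond the scatter) accompanied the move from an aryl to a saturated ring, a step of similar size in the opposite direction is expected: a number 14 percentage points higher from compound 2 to compound 3 (beyond the scatter). Compound 3 is estimated at 72%, with a range from 55% to 90%.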

Compound 3, largest response reached (reported as efficacy), in percent of the reference or control that the assay uses: 66%
Compound 3: middle estimate off by 6 percentage points, on the high side; low and high end bracket the measured number.
By their numbers in this assay, from the lowest: compounds 2, 3 and 1 (each within the scatter of the next, the first and the last beyond it).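

In this assay compound 3 cannot be told apart from either earlier compound: a number 8 percentage points higher from compound 2 to compound 3 (within the scatter) and a number 9 percentage points lower from compound 1 to compound 3 (within the scatter) both stay within the scatter. The gap between compound 1 and compound 2 therefore does not resolve into a clean split between aromatic and saturated rings on the amide-type nitrogen, since compound 3 falls on neither side. Nothing available bears on a cause for these numbers. Still open, as far as these compounds go, is whether an unsubstituted phenyl or a benzyl group on this nitrogen would track compound 1 or compound 2.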